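Pyridin-2-ylmethoxy in place of 4-bromobenzyloxy on the pyridone

The compounds below may be only part of what the source reports. "The series", "measured", "known", "first", "only" and "open" are said of these compounds alone.

Within the data shown here, compound 1 `Cc1c(C2CC2)nc2ccc(-n3ccc(OCc4ccc(Br)cc4)cc3=O)cn12` is the only member with a measured number: in an assay on CHO cells for displacement of a labelled ligand from melanin-concentrating hormone receptor 1 (Rattus norvegicus), read by scintillation counting, with a stated time of 1 h (a lower number here means a stronger inhibitor, a higher number a weaker inhibitor), compound 1 gives 9.3 nM. Compound 2 `Cc1c(CO)nc2ccc(-n3ccc(OCc4ccc(F)cc4)cc3=O)cn12` returns only the assay limit, > 1000 nM, which is not a number. Compound 2 differs from compound 1 in two places, so no single step can be read from the pair. Compound 3 `Cc1c(C2CC2)nc2ccc(-n3ccc(OCc4ccccn4)cc3=O)cn12` carries pyridin-2-yl in place of 4-bromophenyl on a saturated chain carbon bound to an oxygen on an aromatic ring. Among the measured compounds shown here, no measured step covers this change. A loss of potency beyond the usual scatter is expected, moderate in size, with the expected step being a 6.5-fold higher number from compound 1 to compound 3 (0.81 log units; beyond the scatter). For compound 3 the estimate is 60 nM, within 15 nM to 400 nM.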

Compound 3, half-maximal inhibitory concentration: 150 nM
Compound 3: the middle estimate sits 2.5-fold (0.40 log units) below what was measured; measured number inside the range.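

Among these compounds, the first readable step at this position is a 16-fold higher number from compound 1 to compound 3 (1.21 log units; beyond the scatter), so pyridin-2-yl does not stand in for 4-bromophenyl on this saturated chain carbon without a large loss. Compound 3 still returns a number in this assay, so this change alone does not take the core of compound 1 to the assay limit: the limit of > 1000 nM in this assay, at which 1 of the 3 values shown sits.

From the compounds shown here alone, both the bromine and the ring carbon replaced by nitrogen change in this one step, and their shares of the loss remain open. An unsubstituted phenyl on the same carbon would separate the two.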